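Positional isomer of a chlorophenyl group in a cytotoxicity assay

The source may report more compounds than this note shows. Statements on the series, on what has been measured and on what is new or still open speak of the compounds shown alone.

Measured compounds:
- compound 1, `Oc1cccc(-c2cc(-c3ccncc3)nc(-c3cccc(Cl)c3)c2)c1`: "not determined" (no result reported) in an ADME assay on HEK293 cells (Homo sapiens) for cytotoxicity, read by CCK-8 assay and cell counting, with a stated time of 2 days; on this read-out higher numbers stand for weaker inhibition and lower numbers for stronger inhibition
- compound 2, `Oc1cccc(-c2cc(-c3cccc(Cl)c3)nc(-c3ccccn3)c2)c1`: "not determined" (no result reported) in this assay
- compound 3, `Oc1cccc(-c2cc(-c3ccc(Cl)cc3)nc(-c3ccsc3)c2)c1`: 11200 nM

Among the compounds with values here, compound 3 is the only member of the set with a number in this assay; compound 1 and compound 2 carry no result, so there is nothing to rank compound 3 against, and no step between measured compounds is available. Compound 3 gives 11200 nM in this assay, a weak inhibition of cell growth.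

Compound 4, `Oc1cccc(-c2cc(-c3ccsc3)nc(-c3cccc(Cl)c3)c2)c1`, is not yet measured. It differs from compound 3 only in the placement of the chlorine: 3-chlorophenyl in place of 4-chlorophenyl on an aromatic carbon, on an aromatic carbon of the shared core. The two compounds are built from the same atoms joined differently.

Within the data shown here, with no measured step to lean on, the expectation rests on compound 3 alone. The step from compound 3 to compound 4 is expected to stay within the scatter of repeated measurements, a 1.0-fold lower number from compound 3 to compound 4 (0.01 log units; within the scatter), in no particular direction. Compound 4 is therefore estimated at 11000 nM, with a range from 4500 nM to 27000 nM.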

Compound 4, half-maximal inhibitory concentration: 3180 nM
For compound 4 the middle estimate is 3.5-fold (0.54 log units) above the measured one, and the stated range ends above it.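

In this assay the swap of 4-chlorophenyl for 3-chlorophenyl, on the aromatic carbon next to the ring nitrogen, gives a 3.5-fold lower number from compound 3 to compound 4 (0.55 log units; beyond the scatter), so the read-out at this position responds to where the chlorine sits on the phenyl ring, even with the same atoms on both sides of the step. Within the data shown here, this modest step is the only one in the set that can be read, as compound 1 and compound 2 carry no result, and the earlier compounds could show nothing about this position. Nothing available here bears on what lies behind the step.

On these data alone, whether an amine or a methoxy group in place of the chlorine would move the number in the same way stays open. So does whether this one step holds beyond the thiophen-3-yl series.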